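Removing the methoxymethyl from compound 2

The compounds below may be only part of what the source reports. "The series", "measured", "known", "first", "only" and "open" are said of these compounds alone.

Measured compounds:
compound 1, `CS(=O)(=O)Oc1cc(-c2ccccc2)nc2ccccc12`: 6.04 ug/mL
compound 2, `COCOc1ccc(-c2cc(=O)c3ccccc3n2C)cc1`: > 10 ug/mL

The account concerns two measured compounds and one that has not yet been measured, all tested in a functional assay on L1210 (1565) cells (Mus musculus) for cytotoxicity; a higher number here means that more compound is needed for the effect, a lower number that less compound is needed. Compound 1, with the structure `CS(=O)(=O)Oc1cc(-c2ccccc2)nc2ccccc12`, gives 6.04 ug/mL in this assay. Compound 2, with the structure `COCOc1ccc(-c2cc(=O)c3ccccc3n2C)cc1`, returns only a limit in this assay, namely > 10 ug/mL, so no number is known for it; this is the limit of > 10 ug/mL in this assay, at which 1 of the 2 values shown sits. Compound 1 and compound 2 differ in more than one place, so nothing is said here about a step between them beyond what their two values show.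

The unmeasured compound is compound 3, `Cn1c(-c2ccc(O)cc2)cc(=O)c2ccccc21`. It differs from compound 2 in one place: hydrogen in place of methoxymethyl on an oxygen on an aromatic ring. Because compound 2 gives > 10 ug/mL as a limit, there is no number from which a step to compound 3 can be measured. The step from compound 2 to compound 3 is expected to be small, likely within the scatter, with a result near or at the limit; this expectation is a number no higher from compound 2 to compound 3 (the limit leaves the size open). Compound 3 is thus estimated at 10 ug/mL, in the range 3 ug/mL to 30 ug/mL.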

Compound 3, half-maximal effective concentration: > 10 ug/mL
Compound 3: only a limit was reported; the forecaster's own chance of this, stated with the estimate: 50%; the middle value lies on the limit itself.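

In this assay compound 3 gives > 10 ug/mL, which is a limit and not a number. Compound 2 also returns only a limit, so no step from compound 2 to compound 3 can be read: the limit of > 10 ug/mL in this assay, at which 2 of the 3 values shown sit.

The compounds shown leave open whether hydrogen in place of methoxymethyl on an oxygen on an aromatic ring changes the result in this assay at all.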